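Propyl in place of cyclopropyl at the ether carbon

The source may report more compounds than this note shows. Statements on the series, on what has been measured and on what is new or still open speak of the compounds shown alone.

Measured in a functional assay on cells for antagonist activity at Glucagon receptor (Homo sapiens), read by cAMP accumulation, in the presence of a further agent that is not named here; a higher number here means a weaker inhibitor, a lower number a stronger inhibitor:
- compound 1 `CCCC(Oc1ccc(-n2cc(C(F)(F)F)cn2)c(C)c1)c1ccc(C(=O)NCCC(=O)O)cc1`: 1900 nM
- compound 2 `CCC(Oc1ccc(-n2cc(C(F)(F)F)cn2)cc1)c1ccc(C(=O)NCCC(=O)O)cc1`: a limit of the assay, > 22000 nM
- compound 3 `O=C(O)CCNC(=O)c1ccc(C(Oc2ccc(-n3cc(C(F)(F)F)cn3)cc2)C2CC2)cc1`: 15000 nM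

Among the two plain numbers in this assay, compound 3 stands highest, with compound 1 some way below it, a gap beyond the usual scatter. Compound 2 gave only a limit, (the limit of > 22000 nM in this assay, at which 1 of the 3 values shown sits).

Compound 4 `CCCC(Oc1ccc(-n2cc(C(F)(F)F)cn2)cc1)c1ccc(C(=O)NCCC(=O)O)cc1` differs from compound 3 in one place: propyl in place of cyclopropyl on a saturated chain carbon bound to an aromatic carbon and an oxygen on an aromatic ring. Within the data shown here, the only measured step at that same carbon is an at least 1.4-fold lower number from compound 2 to compound 3 (0.16 log units; that floor lies within the scatter), and its lower bound sits within the scatter, so it is weak guidance. Compound 1 also carries propyl at that carbon and gives 1900 nM, but it bears a further methyl group that compound 4 does not, so its number cannot be carried over directly.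

Taken together, compound 4 is expected to show a 1.9-fold lower number from compound 3 to compound 4 (0.27 log units; within the scatter), a moderate move toward lower numbers. Compound 4 is estimated at 8000 nM, within a range from 2500 nM to 25000 nM.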

Compound 4, antagonist equilibrium constant: 5100 nM
The estimate for compound 4 lay 1.6-fold (0.20 log units) above the measured number; measured number inside the range.
By their numbers in this assay, from the lowest: compound 1; then compound 4; then compound 3. At a limit, above all of these: compound 2.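

In this assay, propyl and cyclopropyl have the same heavy-atom count, yet they are not interchangeable on this saturated chain carbon, with a 2.9-fold lower number from compound 3 to compound 4 (0.47 log units; beyond the scatter). Compound 4 also connects two neighbours: adding methyl at the end of the chain gives an at least 4.3-fold lower number from compound 2 to compound 4 (0.63 log units; beyond the scatter), while removing the methyl on an aromatic carbon gives a 2.7-fold higher number from compound 1 to compound 4 (0.43 log units; beyond the scatter), so both the chain and that methyl matter in this small set. The first of these steps is only a floor, as compound 2 gave a limit and not a number: the limit of > 22000 nM in this assay, at which 1 of the 4 values shown sits.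

As far as these compounds go, whether a longer chain such as butyl, or a branched one such as isopropyl, would lower the number further remains open. So does whether the methyl on an aromatic carbon would have a similar effect alongside cyclopropyl.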